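A few compounds are considered here, and "the series" means these few. Any claim that something is new, unique, unknown or untested is made for them only; others in the source may bear on it.

Working notes on the series in an ADME assay on HUVEC cells (Homo sapiens) for antiproliferative activity, read by MTT assay, with a stated time of 48 h; on this read-out lower numbers stand for stronger inhibition and higher numbers for weaker inhibition.

Among the measured compounds shown here, compound 1, with the structure `Cc1ccc(C)c(-n2nncc2CN2C(=O)C3(C(C#N)=C(N)Oc4c3c3nc5ccccc5nc3c3ccccc43)c3ccccc32)c1`, is one of the two measured members. In this assay compound 1 reaches only the limit of the assay and gives no number, recorded as > 50000 nM.

Compound 2, with the structure `N#CC1=C(N)Oc2c(N)cc3nc4ccccc4nc3c2C12C(=O)N(Cc1cnnn1-c1cccc(C(F)(F)F)c1)c1ccccc12`, shares the core of compound 1. In this assay compound 2 likewise sits at the limit rather than at a measured number, recorded as > 50000 nM. Where compound 2 stands on the numbers shown is therefore only a limit, and the one further value shown is a limit as well: the limit of > 50000 nM in this assay, at which 2 of the 2 values shown sit. For the measured compounds named here, no step between measured compounds can be computed from two limits.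

Compound 3, with the structure `COc1ccc(OC)c(-n2nncc2CN2C(=O)C3(C(C#N)=C(N)Oc4c(N)cc5nc6ccccc6nc5c43)c3ccccc32)c1`, is not yet measured. It differs from compound 2 in one place: 2,5-dimethoxyphenyl in place of 3-(trifluoromethyl)phenyl on an aromatic nitrogen.

With both measured members at the limit, the expected step of a number no higher from compound 2 to compound 3 (the limit leaves the size open) is none beyond the scatter, with compound 3 expected to remain at the limit. The estimate for compound 3 in this assay is 50000 nM, in the range 20000 nM to 150000 nM.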

Compound 3, half-maximal inhibitory concentration: > 50000 nM
Compound 3 gave a limit, no number; the forecaster's own chance of this, stated with the estimate: 75%; the middle value lies on the limit itself.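

No step can be read between compound 2 and compound 3 in this assay, because both give a limit of the assay and not a number: the limit of > 50000 nM in this assay, at which 3 of the 3 values shown sit.

The compounds shown leave open whether 2,5-dimethoxyphenyl and 3-(trifluoromethyl)phenyl differ at all in this assay, and which change to the shared core or its substituents would give a readable number.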